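The compounds below may be only part of what the source reports. "The series", "measured", "known", "first", "only" and "open" are said of these compounds alone.

Measured so far:
compound 1 `O=C1Nc2ccc(S(=O)(=O)N3CCOCC3)cc2/C1=N/c1ccc(O)cc1` — 10400 nM
compound 2 `COc1ccc(-c2c(C#N)c(N)n(/N=C3\C(=O)Nc4ccc(S(=O)(=O)N5CCOCC5)cc43)c(=O)c2C#N)cc1` — 15000 nM

Both numbers come from a functional assay on HepG2 cells (Homo sapiens) for cytotoxicity, read by sulforhodamine B assay, with a stated time of 24 h; a higher number here means a weaker inhibitor, a lower number a stronger inhibitor. Compound 1 gives 10400 nM, and compound 2 gives 15000 nM. Within the data shown here, these two values lie within the scatter of each other, so neither compound can be called the stronger or the weaker, and no step between them is counted. Compound 1 is the point of comparison for what follows.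

Compound 3 `O=C1Nc2ccc(S(=O)(=O)N3CCOCC3)cc2/C1=N/NC(=O)c1ccccc1` has not been measured. It keeps the shared core of compound 1 and differs in one place: benzamido in place of 4-hydroxyphenyl on a double-bonded nitrogen. Both measured compounds carry quite different groups at that same double-bonded nitrogen and still sit in one band of values, which gives no basis for expecting a large move in either direction. The expected step from compound 1 to compound 3 in this assay is therefore small, a 1.3-fold higher number from compound 1 to compound 3 (0.10 log units; within the scatter), within the usual scatter, with the weaker side slightly favoured. Compound 3 is accordingly estimated at 13000 nM, with a range from 4500 nM to 38000 nM.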

Compound 3, half-maximal inhibitory concentration: 18100 nM
Beside the measured number, compound 3's estimate is 1.4-fold (0.14 log units) below it; the range from low to high includes it.
By their numbers in this assay, from the lowest: compounds 1, 2 and 3 (each within the scatter of the next).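

In this assay, benzamido in place of 4-hydroxyphenyl on a double-bonded nitrogen gives a 1.7-fold higher number from compound 1 to compound 3 (0.24 log units; within the scatter), the only step shown so far that changes this position while the rest of the shared core stays fixed. The two groups have one six-membered aromatic ring of carbon only in common, and benzamido also brings a nitrogen and a double bond outside aromatic rings, yet the step does not separate compound 3 from compound 1, so this exchange can be read as giving no measurable difference in this series. Nothing measured here explains why these two groups read alike.

Going by these compounds, both groups compared at this place carry that aromatic ring, so it remains open how an amine, a carboxylic acid or a longer alkyl chain on the double-bonded nitrogen would read, and the same holds for a methoxy group or a chlorine on the ring of benzamido. Also open, on these data alone, is whether any change at this position can move the number beyond the scatter in this assay.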